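Halogen removal on the shared core: compound 3

The compounds below may be only part of what the source reports. "The series", "measured", "known", "first", "only" and "open" are said of these compounds alone.

Measured compounds:
Compound 1 `CN1CCN(c2cn(S(=O)(=O)c3ccccc3Br)c3ccc(Br)cc23)CC1`: 10.2 nM
Compound 2 `CN1CCN(c2cn(S(=O)(=O)c3ccccc3Br)c3cc(Cl)ccc23)CC1`: 30.2 nM

Both compounds were characterised in an assay on HeLa cells for displacement of a labelled ligand from 5-hydroxytryptamine receptor 6 (Homo sapiens); a lower number here means a stronger inhibitor, a higher number a weaker inhibitor. Compound 2 gives 30.2 nM, the higher of the two numbers on record; compound 1 gives 10.2 nM, and the gap between them lies beyond the scatter. Going by the values given here, no step between measured compounds differing in a single place is available, so the series offers no direct calibration for a halogen removal.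

Compound 3 `CN1CCN(c2cn(S(=O)(=O)c3ccccc3Br)c3ccccc23)CC1` is the unmeasured member. It differs from compound 2 in one place: hydrogen in place of chloro on an aromatic carbon. Without a measured analogue of this exchange, the expectation rests on the two values alone, which show a chloro-bearing compound at the weaker end and a bromo-bearing compound at the stronger end. A modest change is expected from compound 2 to compound 3, of size a 1.4-fold lower number from compound 2 to compound 3 (0.14 log units; within the scatter), not clearly beyond the scatter in either direction. Compound 3 is therefore estimated at 22 nM in this assay, with a range from 7 nM to 70 nM.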

Compound 3, inhibition constant: 15.2 nM
Beside the measured number, compound 3's estimate is 1.4-fold (0.16 log units) above it; measured number inside the range.
By their numbers in this assay, from the lowest: compounds 1, 3 and 2 (each within the scatter of the next, the first and the last beyond it).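

In this assay, going by these compounds alone, a step of a 2.0-fold lower number from compound 2 to compound 3 (0.30 log units; within the scatter) gives the first single-place reading for this position: hydrogen in place of chloro on an aromatic carbon, meta to a fused ring and para to a fused ring, leaves the number within the scatter. The second reading, a 1.5-fold higher number from compound 1 to compound 3 (0.17 log units; within the scatter) on removal of the bromo, also stays within the scatter, so compound 3 cannot be separated from either halogen-bearing partner. Neither the chloro nor the bromo is therefore required on the shared core for binding of the order shown by compound 3 at 15.2 nM in this assay and the halogen at these places carries no resolved weight in these three compounds.

Open, going by these compounds, is whether a non-halogen group at the chloro position, such as a methoxy, a nitrile, a primary amine or a carboxylic acid, would move the number beyond the scatter, and whether the bromo kept by all three compounds matters more than the halogens removed here. No supporting measurement speaks to the reason for these steps.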